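Bromo to fluoro swap on a second ester core

A few compounds are considered here, and "the series" means these few. Any claim that something is new, unique, unknown or untested is made for them only; others in the source may bear on it.

Compound 1, `CS(=O)(=O)c1ccc(-c2nc(SCCCOC(=O)/C=C/c3ccc(O)c(O)c3)nn2-c2ccc(Br)cc2)cc1`, gives 11200 nM in a functional assay on A549 cells (Homo sapiens) for antiproliferative activity, read by MTT assay, with a stated time of 72 h; on this read-out lower numbers stand for stronger inhibition and higher numbers for weaker inhibition. Compound 2, `CS(=O)(=O)c1ccc(-c2nc(SCCCOC(=O)/C=C/c3ccc(O)c(O)c3)nn2-c2ccc(F)cc2)cc1`, gives 9520 nM in this assay. Compound 3, `COc1cc(/C=C/C(=O)OCCSc2nc(-c3ccc(S(C)(=O)=O)cc3)n(-c3ccc(Br)cc3)n2)ccc1OC(C)=O`, gives 11100 nM in this assay.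

Compound 1 and compound 2 differ only by fluoro in place of bromo on an aromatic carbon, and the step is a 1.2-fold lower number from compound 1 to compound 2 (0.07 log units; within the scatter). Compound 4, `COc1cc(/C=C/C(=O)OCCSc2nc(-c3ccc(S(C)(=O)=O)cc3)n(-c3ccc(F)cc3)n2)ccc1OC(C)=O`, differs from compound 3 by fluoro in place of bromo on an aromatic carbon, the same change at the same kind of place. How the core of compound 3 differs from that of compound 1 is not broken down here; the two measured values of compound 1 and compound 3 are within the scatter of each other. Among the compounds with values here, since the only measured instance of this change left the value essentially unmoved, compound 4 is expected to sit near compound 3, with an expected step of a 1.2-fold lower number from compound 3 to compound 4 (0.07 log units; within the scatter) because of a 1.2-fold lower number from compound 1 to compound 2 (0.07 log units; within the scatter). The estimate for compound 4 in this assay is 9500 nM, expected to fall between 5500 nM and 17000 nM.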

Compound 4, half-maximal inhibitory concentration: 9610 nM
Compound 4: the middle estimate sits 1.0-fold (0.00 log units) below what was measured; low and high end bracket the measured number.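

In this assay, the change from 4-bromophenyl to 4-fluorophenyl on the second core reads as a 1.2-fold lower number from compound 3 to compound 4 (0.06 log units; within the scatter). The two cores give steps of matching size, and neither step leaves the scatter: the same change on two cores in this assay, a 1.2-fold lower number (0.07 log units; within the scatter) from compound 1 to compound 2 and a 1.2-fold lower number (0.06 log units; within the scatter) from compound 3 to compound 4, 1.0-fold (0.01 log units) apart, within the scatter of two such steps. This shows that fluoro in place of bromo left the value unmoved on both cores, but it does not show that the swap would stay flat on any other core in the series, or that the group at this place has no bearing on the value.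

Still open, going by these compounds, is whether an amine or a carboxylic acid in place of the halogen would move the value beyond the scatter. On these data alone, the cores differ in more than one place, so what each of those differences does alone also stays open.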